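A few compounds are considered here, and "the series" means these few. Any claim that something is new, unique, unknown or untested is made for them only; others in the source may bear on it.

Measured compounds:
- Compound 1 `CN(C)C(=O)CN1CCC(Oc2ncnc3c2CCN3c2ccc(S(C)(=O)=O)cc2F)CC1` — > 10000 nM
- Compound 2 `Cc1nc(OC2CCN(C(=O)OC(C)C)CC2)c2c(n1)N(c1ccc(S(C)(=O)=O)cc1F)CC2` — 100 nM
- Compound 3 `CC(C)OC(=O)N1CCC(Oc2ncnc3c2CCN3c2ccc(C#N)cn2)CC1` — 794 nM

Of the compounds shown here, three sharing one core have been tested in a functional assay on CHO-K1 cells for agonist activity at Glucose-dependent insulinotropic receptor (Homo sapiens), read by a luciferase reporter, with a stated time of 5 h; a higher number here means that more compound is needed for the effect, a lower number that less compound is needed. Compound 1 gives > 10000 nM, which is a limit of the assay rather than a number (the limit of > 10000 nM in this assay, at which 1 of the 3 values shown sits). Among the two compounds with a number, compound 3 stands highest with 794 nM; compound 2, at 100 nM, sits lower by a gap that is beyond the usual scatter of repeated measurements.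

Compound 4 `CC(C)OC(=O)N1CCC(Oc2ncnc3c2CCN3c2ccc([S@+](C)[O-])c(F)c2)CC1` has not yet been measured. It differs from compound 3 by a group of 10 heavy atoms (7 carbon, 1 oxygen, 1 fluorine, 1 sulfur; one six-membered aromatic ring of carbon only) in place of a group of 8 heavy atoms (6 carbon, 2 nitrogen; one six-membered aromatic ring with 1 hetero atom), on a nitrogen on an aromatic ring in a ring. Among the compounds with values here, compound 2 carries an aromatic ring of carbon only at the same part of the core and shows the lower number, so the change in compound 4 is expected to move the value downward rather than upward, but no measured pair isolates this exact swap. The expected step of a 2.6-fold lower number from compound 3 to compound 4 (0.42 log units; beyond the scatter) is therefore a modest one, in the direction of a lower number. Compound 4 is estimated at 300 nM, within a range from 60 nM to 1500 nM.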

Compound 4, half-maximal effective concentration: 50.1 nM
Compound 4: the middle estimate sits 6.0-fold (0.78 log units) above what was measured, and the stated range ends above it.
By their numbers in this assay, from the lowest: compounds 4 and 2 (each within the scatter of the next); then compound 3. At a limit, above all of these: compound 1.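

In this assay, putting an aromatic ring of carbon only, carrying fluorine and a sulfur-and-oxygen group, in place of the 5-cyanopyridin-2-yl group gives a 16-fold lower number from compound 3 to compound 4 (1.20 log units; beyond the scatter). This is the first step shown that changes a single place, and it shows that the group on this nitrogen of the five-membered non-aromatic ring can move the value well beyond the usual scatter. Nothing shown here gives a reason for the size of this step.

One swap cannot tell which part of the change carries the step: the fluorine, the sulfur-and-oxygen group, or the loss of the nitrile and the pyridine nitrogen. Going by these compounds, it also remains open how the opposite arrangement at the stereocentre would read, or how a plain phenyl ring or one bearing an amine or a carboxylic acid would read at this nitrogen.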